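The source may hold more compounds than are shown below. What is called first, only, known or untested is meant among the compounds shown, and "the series" means these compounds.

Compound 2 `COc1ccc(N2C(=O)[C@H]3[C@H](ON4[C@@H]3C(=O)N(C)[C@@]43C[C@H](C)CC[C@H]3C(C)C)C2=O)cc1` gives 48.1% in a functional assay, with a stated time of 20 min, tested at 1 mg/mL (a higher number here means a stronger effect of the compound at the concentration tested, a lower number a weaker effect), the higher of the two numbers recorded, while compound 1 `CC(C)[C@@H]1CC[C@@H](C)C[C@@]12N(C)C(=O)[C@@H]1[C@H]3C(=O)NC(=O)[C@H]3ON12` gives 39.3%; the step of a number 8.8 percentage points higher from compound 1 to compound 2 (within the scatter) stays within the scatter. Compound 3 `CC(C)[C@@H]1CC[C@@H](C)C[C@@]12N(C)C(=O)[C@@H]1[C@H]3C(=O)N(c4ccc5ccccc5c4)C(=O)[C@H]3ON12` carries naphthalen-2-yl in place of 4-methoxyphenyl on an amide-type nitrogen in a ring. Among the compounds with values here, the only measured step that touches this nitrogen is the one from compound 1 to compound 2, and it did not exceed the scatter. Compound 3 is therefore expected to show no step beyond the scatter, a number 1.9 percentage points higher from compound 2 to compound 3 (within the scatter), in this assay. The estimate for compound 3 is 50%, ranging from 30% to 70%.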

Compound 3, a percentage reported as activity, at one concentration (the size of the read-out at that concentration, not a potency): 27.6%
The estimate for compound 3 lay 22.4 percentage points above the measured number; the measured number lies below the stated range.
By their numbers in this assay, from the lowest: compound 3; then compounds 1 and 2 (each within the scatter of the next).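

In this assay, the amide-type nitrogen proved not to be indifferent to the aryl group it carries: naphthalen-2-yl in place of 4-methoxyphenyl gives a number 20.5 percentage points lower from compound 2 to compound 3 (beyond the scatter), and naphthalen-2-yl in place of hydrogen gives a number 11.7 percentage points lower from compound 1 to compound 3 (beyond the scatter). Within the data shown here, the earlier step to 4-methoxyphenyl had stayed within the scatter, so this is the first change at this nitrogen to register beyond it. Nothing measured here accounts for the loss. On these data alone, it remains open how a plain phenyl or a benzyl group on this nitrogen would compare, and whether a 1-naphthyl group would behave like naphthalen-2-yl.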